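The source may report more compounds than this note shows. Statements on the series, on what has been measured and on what is new or still open speak of the compounds shown alone.

Measured so far in an ADME assay on microsomes from liver (Homo sapiens) for metabolic stability, read by LC-MS, using NADPH, with a stated time of 30 min, tested at 0.5 uM; a higher number here means faster removal of the compound, a lower number slower removal: compound 1 `COc1ccc2nc(C)cc(OCC(=O)Nc3cccc(C)c3)c2c1`, 2.5 mL.min-1.g-1; compound 2 `COc1ccc2nc(C)cc(OCC(=O)Nc3cc(C)ccc3C)c2c1`, 2.3 mL.min-1.g-1.

Compound 2 and compound 1 sit within the scatter of each other, the step being a 1.1-fold lower number from compound 1 to compound 2 (0.04 log units; within the scatter) for methyl in place of hydrogen on an aromatic carbon. Compound 3 `COc1ccc2nc(C)cc(OCC(=O)Nc3cc(C)c(F)c(C)c3)c2c1` carries 4-fluoro-3,5-dimethylphenyl in place of 2,5-dimethylphenyl on an amide-type nitrogen. Among the compounds with values here, only that one step bears on it, and it was within the scatter, so no step beyond the scatter is expected in this assay for compound 3; the expected step is no change at the digits printed from compound 2 to compound 3 (within the scatter). The estimate for compound 3 is 2.3 mL.min-1.g-1, with a range from 1.2 mL.min-1.g-1 to 4.5 mL.min-1.g-1.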

Compound 3, intrinsic clearance in microsomes: 1.1 mL.min-1.g-1
Compound 3: the middle estimate sits 2.1-fold (0.32 log units) above what was measured; measured number outside the range, below it.
By their numbers in this assay, from the lowest: compound 3; then compounds 2 and 1 (each within the scatter of the next).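

Within the data shown here, on the amide-type nitrogen, 4-fluoro-3,5-dimethylphenyl gives the first change beyond the scatter in this assay, with a 2.1-fold lower number from compound 2 to compound 3 (0.32 log units; beyond the scatter) and a 2.3-fold lower number from compound 1 to compound 3 (0.36 log units; beyond the scatter). The group on this nitrogen can therefore move the number, which the added methyl of compound 2 did not show. No supporting data bear on the reason for this shift.

Compound 3 does not separate the contribution of the fluorine from that of the placement of the methyl groups. From the compounds shown here alone, how an amine or a carboxylic acid on this phenyl ring would read remains open.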